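The compounds below may be only part of what the source reports. "The series", "measured", "known", "first", "only" and "open" are said of these compounds alone.

Compound 1 `CC(C)=CCC/C(C)=C/CC/C(C)=C/CSC[C@H](NC(=O)CCCCCN1CCN(C)CC1)C(=O)N1CCCC1` gives 6000 nM in a functional assay on MIA PaCa-2 cells (Homo sapiens) for cytotoxicity, read by fluorescence, with a stated time of 48 h (on this read-out lower numbers stand for an effect already at smaller amounts and higher numbers for an effect only at larger amounts of compound), the lowest of the three numbers measured. Compound 2 `CC(C)=CCC/C(C)=C/CC/C(C)=C/CSC[C@H](NC(=O)CCCCCN1CCN(C)CC1)C(=O)NC1CCCC1` gives 10900 nM in this assay, with a 1.8-fold higher number from compound 1 to compound 2 (0.26 log units; within the scatter), and compound 3 `CC(C)=CCC/C(C)=C/CC/C(C)=C/CSC[C@H](NC(=O)CCCCCN1CCN(C)CC1)C(=O)N1CCCCC1` gives 14300 nM in this assay, with a 2.4-fold higher number from compound 1 to compound 3 (0.38 log units; beyond the scatter). Compound 4 `CC(C)=CCC/C(C)=C/CC/C(C)=C/CSC[C@H](NC(=O)CCCCCN1CCCC1)C(=O)N1CCCC1` differs from compound 1 in a different place: pyrrolidin-1-yl in place of 4-methylpiperazin-1-yl on a saturated chain carbon, five bonds along the chain from a carbonyl carbon. Every measured step concerns the group on the carbonyl carbon, so none of them bears on a change on the saturated chain carbon, and the data give no direct guide to its size or direction. Compound 4 is therefore expected to give about 6500 nM in this assay, within 2500 nM to 17000 nM. The expected step is a 1.1-fold higher number from compound 1 to compound 4 (0.03 log units; within the scatter), not beyond the scatter.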

Compound 4, half-maximal effective concentration: 10800 nM
Beside the measured number, compound 4's estimate is 1.7-fold (0.22 log units) below it, and the stated range covers the measured number.
By their numbers in this assay, from the lowest: compounds 1, 4, 2 and 3 (each within the scatter of the next, the first and the last beyond it).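

In this assay, within the data shown here, the swap of 4-methylpiperazin-1-yl for pyrrolidin-1-yl gives a 1.8-fold higher number from compound 1 to compound 4 (0.26 log units; within the scatter) and so offers the first reading at this saturated chain carbon, five bonds along the chain from a carbonyl carbon. At this position, then, the second ring nitrogen with its methyl group can be lost without a change beyond the scatter. Nothing shown explains the size of this step. The compounds shown leave open how an open-chain amine such as dimethylamino, a morpholin-4-yl ring or a carboxylic acid would read at this position. They also leave open whether a shorter or longer chain would alter the number.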